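The source may report more compounds than this note shows. Statements on the series, on what has been measured and on what is new or still open speak of the compounds shown alone.

Compound 1 `COc1ccc(-n2nc(-c3ccccc3)nc2CNc2ccc(C(=O)NO)cc2)cc1` is tested in an assay on Sf9 cells for inhibition of protein deacetylase HDAC6 (Homo sapiens), read by fluorescence, with a stated time of 40 min, tested at 100 nM (on this read-out higher numbers stand for more inhibition at the one concentration tested (going by the name of the read-out) and lower numbers for less inhibition), where compound 1 gives 63.4%. Among the three measured compounds this is the second highest number. Its nearest neighbour is compound 2 `COc1ccc(-n2nc(-c3ccc(O)cc3)nc2CNc2ccc(C(=O)NO)cc2)cc1`, which differs only by a hydroxy in place of hydrogen on an aromatic carbon and in this assay gives 70.3%. The step between them is a number 6.9 percentage points higher from compound 1 to compound 2 (within the scatter). The furthest is compound 3 `CC(C)c1ccc(-c2nc(CNc3ccc(C(=O)NO)cc3)n(-c3ccccc3)n2)cc1`, which differs from compound 1 in several places at once. In this assay compound 3 gives 27.6%. Among the measured compounds shown here, that number lies beyond the scatter below the one given by compound 1.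

Compound 4 `CCc1ccc(-n2nc(-c3ccccc3)nc2CNc2ccc(C(=O)NO)cc2)cc1` has not yet been measured. It differs from compound 1 by ethyl in place of methoxy on an aromatic carbon. For the measured compounds named here, no measured step touches this change: the only single-place step, from compound 1 to compound 2, concerns a different group and lies within the scatter, and compound 3 is not a single-place comparison. Going by the values given here, with no measured step on a methoxy-to-ethyl exchange, there is no ground to expect a movement beyond the scatter, so the expected step is a number 5.4 percentage points lower from compound 1 to compound 4 (within the scatter). For compound 4 in this assay the estimate is 58%, with a range from 40% to 75%.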

Compound 4, a percentage reported as inhibition, at one concentration (the size of the read-out at that concentration, not a potency): 38.3%
Beside the measured number, compound 4's estimate is 19.7 percentage points above it; measured number outside the range, below it.
By their numbers in this assay, from the lowest: compound 3; then compound 4; then compounds 1 and 2 (each within the scatter of the next).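

In this assay this position responds to a small exchange: the step is a number 25.1 percentage points lower from compound 1 to compound 4 (beyond the scatter) with ethyl in place of methoxy on an aromatic carbon para to a large group. Among the compounds shown here, the one single-place step known before, a hydroxy added elsewhere in the molecule, stayed within the scatter, so this is the first sign that one small change to the shared core can move the number by more than the usual variation, even though methoxy and ethyl have the same count of heavy atoms and differ in that methoxy counts a hydrogen-bond acceptor and ethyl none. Nothing measured here tells why the number falls with this exchange.

As far as these compounds go, it remains open whether the oxygen itself matters or whether ethyl is the group that lowers the number, a question that a hydroxy, a methyl, an amine or a longer chain such as propyl at this place could help to settle. Also open, from the compounds shown here alone, is whether the same exchange would give a similar step alongside the hydroxy of compound 2, and how the step would look at concentrations other than the single one tested.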